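A few compounds are considered here, and "the series" means these few. Any claim that something is new, unique, unknown or untested is made for them only; others in the source may bear on it.

Of the compounds shown here, three sharing one core have been measured. Compound 1 `CCCCc1csc(CN[C@@H]2C[C@H]3C[C@@H]([C@H]2C)C3(C)C)c1` carries a butyl chain on its thiophene. In an ADME assay on MDCK cells (Canis lupus familiaris) for cytotoxicity, read by microscopy, with a stated time of 48 h (a higher number here means that more compound is tolerated, a lower number that less compound is tolerated), compound 1 gives 12500 nM. Compound 3 `C[C@H]1[C@H](NCc2sccc2-c2ccccc2)C[C@H]2C[C@@H]1C2(C)C`, with a phenyl on the ring, gives 12500 nM in this assay, no different from compound 1 within the scatter, so these two share the highest reading of the three. Compound 2 `Cc1ccc(CN[C@@H]2C[C@H]3C[C@@H]([C@H]2C)C3(C)C)s1`, with only a methyl, gives 780 nM in this assay, a clearly lower number than compound 1. Compound 4 `C[C@H]1[C@H](NCc2cc(-c3ccsc3)cs2)C[C@H]2C[C@@H]1C2(C)C` is not yet measured; it differs from compound 1 as follows: thiophen-3-yl in place of butyl on an aromatic carbon. Since an aromatic substituent in compound 3 gave 12500 nM, no step beyond the scatter is expected, that is a 1.3-fold lower number from compound 1 to compound 4 (0.10 log units; within the scatter). Compound 4 is therefore estimated at 10000 nM, ranging from 3000 nM to 25000 nM.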

Compound 4, minimum cytotoxic concentration: 25000 nM
Compound 4: the middle estimate sits 2.5-fold (0.40 log units) below what was measured; the range from low to high includes it.
By their numbers in this assay, from the lowest: compound 2; then compounds 1, 3 and 4 (each within the scatter of the next).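

In this assay, going by these compounds alone, putting thiophen-3-yl in place of butyl on this aromatic carbon gives a 2.0-fold higher number from compound 1 to compound 4 (0.30 log units; within the scatter), the first step in this set that changes one place only. At this position, then, an open chain and a five-membered aromatic ring with one sulfur read alike. Nothing available explains this reading. From the compounds shown here alone, whether a group carrying an amine or a carboxylic acid at this position would read the same remains open.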